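A few compounds are considered here, and "the series" means these few. Any claim that something is new, unique, unknown or untested is made for them only; others in the source may bear on it.

Measured in a functional assay on PC-3 cells (Homo sapiens) for cytotoxicity, read by sulforhodamine B assay, with a stated time of 48 h; a lower number here means a stronger inhibitor, a higher number a weaker inhibitor:
- Compound 1 `C[C@H]1CC[C@@H]2[C@@H](OC(=O)[C@]23CC(c2ccc(Cl)cc2)=NO3)[C@]2(C)C(=O)C=C[C@@]12O`: 49000 nM
- Compound 2 `C[C@H]1CC[C@@H]2[C@@H](OC(=O)[C@]23CC(c2ccc([N+](=O)[O-])cc2)=NO3)[C@]2(C)C(=O)C=C[C@@]12O`: 12000 nM
- Compound 3 `COc1ccc(C2=NO[C@]3(C2)C(=O)O[C@@H]2[C@H]3CC[C@H](C)[C@]3(O)C=CC(=O)[C@@]23C)cc1OC`: 25000 nM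

Two steps fix the place of compound 3 among these numbers: a 2.0-fold lower number from compound 1 to compound 3 (0.29 log units; within the scatter), and a 2.1-fold higher number from compound 2 to compound 3 (0.32 log units; beyond the scatter). Compound 4 `C[C@H]1CC[C@@H]2[C@@H](OC(=O)[C@]23CC(c2cccc([N+](=O)[O-])c2)=NO3)[C@]2(C)C(=O)C=C[C@@]12O` differs from compound 3 by 3-nitrophenyl in place of 3,4-dimethoxyphenyl on a carbon with a double bond to nitrogen, with 3-nitrophenyl in place of 3,4-dimethoxyphenyl on a carbon with a double bond to nitrogen. For the measured compounds named here, no measured compound carries 3-nitrophenyl. The closest guide is compound 2, with 4-nitrophenyl, at 12000 nM, and the other nitro step is a 4.1-fold lower number from compound 1 to compound 2 (0.61 log units; beyond the scatter). A modest move to a lower number is therefore expected in this assay, and it may not clear the scatter. The estimated step is a 1.7-fold lower number from compound 3 to compound 4 (0.22 log units; within the scatter). Compound 4 is estimated at 15000 nM, within a range of 7000 nM to 32000 nM.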

Compound 4, half-maximal inhibitory concentration: 55000 nM
Beside the measured number, compound 4's estimate is 3.7-fold (0.56 log units) below it, outside the stated range (above it).
By their numbers in this assay, from the lowest: compound 2; then compounds 3, 1 and 4 (each within the scatter of the next, the first and the last beyond it).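

In this assay, the place of the nitro group on the phenyl ring matters: 3-nitrophenyl in place of 4-nitrophenyl gives a 4.6-fold higher number from compound 2 to compound 4 (0.66 log units; beyond the scatter) and so reverses the direction of the nitro step seen earlier. Against the 3,4-dimethoxyphenyl compound the change gives a 2.2-fold higher number from compound 3 to compound 4 (0.34 log units; beyond the scatter) while the 4-chlorophenyl comparison gives a 1.1-fold higher number from compound 1 to compound 4 (0.05 log units; within the scatter) and separates nothing. Nothing available accounts for the gap between the two nitrophenyl groups. The compounds shown leave open whether 3-chlorophenyl would differ from 4-chlorophenyl in the same way. They also leave open how an amine or a carboxylic acid on this ring would read.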